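The compounds below may be only part of what the source reports. "The series", "measured", "known", "first", "only" and "open" are said of these compounds alone.

Compound 1 `COc1cc(C(=O)N2CCCC(N(C)C)c3sccc32)ccc1NC(=O)c1ccccc1-c1ccccc1` and compound 2 `O=C(Nc1ccc(C(=O)N2CCCN(CCN3CCCC3)c3sccc32)cc1)c1ccccc1-c1ccccc1` share the same core and were both examined in a functional assay on the whole organism for antagonist activity, with Rattus norvegicus as the target; on this read-out higher numbers stand for an effect only at larger amounts of compound and lower numbers for an effect already at smaller amounts. In this assay compound 1 reaches only a limit of the measurement, > 0.3 mg/kg. Compound 2 likewise gives only a limit in this assay, > 0.3 mg/kg, so its standing is known merely as this bound and not as a number. Both measured values sit at the same bound, (the limit of > 0.3 mg/kg in this assay, at which 2 of the 2 values shown sit). Going by the values given here, no step between two measured compounds can therefore be read from these data. Compound 3 `CN(C)CCN1CCCN(C(=O)c2ccc(NC(=O)c3ccccc3-c3ccccc3)cc2)c2ccsc21` differs from compound 2 by dimethylamino in place of pyrrolidin-1-yl on a saturated chain carbon, two bonds along the chain from a nitrogen on an aromatic ring in a ring. Without a measured step to lean on, the change from compound 2 to compound 3 is expected to stay within the usual scatter, in no particular direction. Compound 3 is thus estimated at 0.5 mg/kg in this assay, ranging from 0.25 mg/kg to 1.5 mg/kg. The expected step that the limit leaves unreadable from compound 2 to compound 3 is estimated to be no more than scatter, and another limit is likely.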

Compound 3, dose for 50% inhibition: 0.31 mg/kg
Compound 3: the middle estimate sits 1.6-fold (0.21 log units) above what was measured; the measured number falls inside the stated range.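

Compound 2 stands only as a limit in this assay, > 0.3 mg/kg, so no step to compound 3 can be read: the limit of > 0.3 mg/kg in this assay, at which 2 of the 3 values shown sit.

The compounds shown leave open whether dimethylamino in place of pyrrolidin-1-yl on this chain shifts the dose at all, and in which direction.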